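The compounds below may be only part of what the source reports. "The series", "measured", "known", "first", "only" and "open" are said of these compounds alone.

Compound 1, `COc1ccc(NC(=O)C2CCc3ccccc3N2)cc1`: 50200 nM
Compound 3, `O=C(Nc1ccccc1O)C1CCc2ccccc2N1C(=O)c1ccccc1`: 3830 nM
Compound 2, `CC(=O)N1c2ccccc2CCC1C(=O)Nc1cc(C(F)(F)F)cc(C(F)(F)F)c1`: > 70000 nM

These three compounds were tested in a functional assay on HCT-15 cells (Homo sapiens) for cytotoxicity, read by sulforhodamine B assay, with a stated time of 72 h; on this read-out higher numbers stand for weaker inhibition of growth and lower numbers for stronger inhibition of growth. Compound 1 and compound 3 each return a number in this assay. For compound 2 the result is a limit of the assay and not a number, so compound 2 stands at the limit of > 70000 nM in this assay, at which 1 of the 3 values shown sits, the weakest reading the assay reports.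

Compound 4, `CCCC(=O)N1c2ccccc2CCC1C(=O)Nc1cc(C(F)(F)F)cc(C(F)(F)F)c1`, has not yet been measured. It differs from compound 2 in one place: ethyl in place of hydrogen on a saturated chain carbon bound to a carbonyl carbon. No measured pair of compounds differs in a single place, so nothing shown tells what such a change does in this assay. With compound 2 at the limit, the step expected is an at least 1.1-fold lower number from compound 2 to compound 4 (0.06 log units; that floor lies within the scatter), nothing beyond the usual scatter. Compound 4 is therefore estimated at 60000 nM, with a range from 20000 nM to 200000 nM.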

Compound 4, concentration for 50% growth inhibition: 21900 nM
Compound 4: the middle estimate sits 2.7-fold (0.44 log units) above what was measured; low and high end bracket the measured number.
By their numbers in this assay, from the lowest: compound 3; then compound 4; then compound 1. At a limit, above all of these: compound 2.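

In this assay, ethyl in place of hydrogen on a saturated chain carbon bound to a carbonyl carbon gives an at least 3.1-fold lower number from compound 2 to compound 4 (0.50 log units; beyond the scatter), the first sign that this position responds to a change at all. Compound 2 gives a limit of the assay and not a number, so the full size of this step cannot be read: the limit of > 70000 nM in this assay, at which 1 of the 4 values shown sits.

On these data alone, whether a longer chain such as butyl, or an amine or a carboxylic acid at this place, would lower the number further stays open. So does whether the step holds with other groups on the amide nitrogen.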